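This account rests on a few compounds, and the source may have more. Where it says the series, first, only, none or still open, it means among the compounds named here.

In a functional assay on the whole organism (blood) with Rattus norvegicus as the target (a lower number here means that less compound is needed, a higher number that more compound is needed for the effect), compound 1 `CCOC(=O)C1(CCCc2cccc(C(F)(F)F)c2)CO1` gives 170 umol/kg as its dose, while compound 2 `CCOC(=O)C1(CCCc2cccc(Cl)c2)CO1` gives 680 umol/kg and so holds the higher of the two numbers. Compound 3 `CCOC(=O)C1(CCCc2ccccc2)CO1` differs from compound 2 by a single change, hydrogen in place of chloro on an aromatic carbon with hydrogen in place of chloro on an aromatic carbon. Among the measured compounds shown here, the only measured step that bears on this is chloro in place of trifluoromethyl on an aromatic carbon, which gave a 4.0-fold higher number from compound 1 to compound 2 (0.60 log units; beyond the scatter) and counts as modest. For the measured compounds named here, no measured compound shows what hydrogen does on that carbon, so this one step is only a loose guide. Losing the chloro is expected to raise the number again by a similar modest amount, an estimated 1.6-fold higher number from compound 2 to compound 3 (0.21 log units; within the scatter) in the same direction as the earlier step. For compound 3 the expected value is 1100 umol/kg within an estimated range of 450 umol/kg to 2800 umol/kg for now.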

Compound 3, dose for half-maximal effect: 1170 umol/kg
Compound 3: the middle estimate sits 1.1-fold (0.03 log units) below what was measured; the measured number falls inside the stated range.
By their numbers in this assay, from the lowest: compound 1; then compounds 2 and 3 (each within the scatter of the next).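

In this assay, hydrogen in place of chloro on this aromatic carbon gives a 1.7-fold higher number from compound 2 to compound 3 (0.24 log units; within the scatter), so the two cannot be told apart at this position, which the earlier pair could not show. Hydrogen in place of trifluoromethyl gives a 6.9-fold higher number from compound 1 to compound 3 (0.84 log units; beyond the scatter), so among these three compounds only the trifluoromethyl compound, compound 1, stands clearly apart, with a lower number than both compound 2 and compound 3. No measured evidence here explains this difference.

As far as these compounds go, it remains open whether other groups on the same aromatic carbon, such as methoxy, fluoro or an amine, would group with trifluoromethyl or with chloro and hydrogen. The compounds shown also leave open how trifluoromethyl would behave on a different carbon of the aromatic ring.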